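The compounds below may be only part of what the source reports. "The series", "measured", "known", "first", "only" and "open" are said of these compounds alone.

Compound 1, `OB1OCc2ccc(-n3cc(Sc4ccc(Cl)c(Cl)c4)c4ccccc43)cc21`, in an ADME assay on L929 cells (Mus musculus) for cytotoxicity, read by resazurin assay, with a stated time of 72 h (on this read-out higher numbers stand for weaker inhibition and lower numbers for stronger inhibition), gives only a limit, > 10 ug/mL.
Compound 2, `OB1OCc2ccc(-n3cc(Sc4ccc5ccccc5c4)c4ccccc43)cc21`, in this assay gives only a limit, > 10 ug/mL.
Compound 3, `OB1OCc2ccc(-n3cccc3)cc21`, in this assay gives only a limit, > 10 ug/mL.

All three measured compounds sit at the limit of > 10 ug/mL in this assay, at which 3 of the 3 values shown sit, so compound 3 stands where the other two stand, at a limit and not at a number. For the measured compounds named here, the one measured step that changes a single place, a step that the two limits leave unreadable from compound 1 to compound 2, cannot be read because both ends are limits, and it concerns a group on the sulfur far from the place changed here.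

Compound 4 is `CNC(=O)c1cccn1-c1ccc2c(c1)B(O)OC2`. It differs from compound 3 by methylcarbamoyl in place of hydrogen on an aromatic carbon. Going by the values given here, no measured step bears on a change at that place, so the expectation rests only on the fact that every measured compound, including compound 3 with > 10 ug/mL, stays at the limit. Among the compounds with values here, compound 4 is therefore expected to show no step in this assay that rises above the scatter, so that a step that the limit leaves unreadable from compound 3 to compound 4 is the estimated step. Compound 4 is estimated at 20 ug/mL, within a range from 10 ug/mL to 60 ug/mL, most likely again reported only as a limit.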

Compound 4, half-maximal inhibitory concentration: > 10 ug/mL
Compound 4: no number, only a limit; the forecaster's own chance of this, stated with the estimate: 85%; the middle value does not contradict the limit.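

For the compounds shown here, compound 3 and compound 4 both give only a limit, so no step between them can be read in this assay: the limit of > 10 ug/mL in this assay, at which 4 of the 4 values shown sit. The compounds shown leave open where any of them would give an actual number, and so what any change of group does.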